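Aminophenyl to Pyridin-3-yl: Expected Cytotoxicity of Compound 3

The source may report more compounds than this note shows. Statements on the series, on what has been measured and on what is new or still open speak of the compounds shown alone.

Compound 1, `Cc1ncc([N+](=O)[O-])n1CCSc1nnc(-c2ccc(N)cc2)o1`, gives 6700 nM in a functional assay on HepG2 cells (Homo sapiens) for cytotoxicity, read by MTT assay, with a stated time of 48 h; on this read-out higher numbers stand for weaker inhibition and lower numbers for stronger inhibition.
Compound 2, `Cc1ncc([N+](=O)[O-])n1CCSc1nnc(-c2ccc(N(C)C)cc2)o1`, gives 11900 nM in this assay.

Among the measured compounds shown here, compound 1 sits at one end of these two numbers, and the only measured step from it, a 1.8-fold higher number from compound 1 to compound 2 (0.25 log units; within the scatter), lies within the scatter. Compound 3, `Cc1ncc([N+](=O)[O-])n1CCSc1nnc(-c2cccnc2)o1`, differs from compound 1 by pyridin-3-yl in place of 4-aminophenyl on an aromatic carbon. For the measured compounds named here, no measured step exchanges one aromatic ring for another, so the step from compound 1 to compound 2 bears on it only loosely, and it was small. Compound 3 is therefore expected to give about 8500 nM, within 3000 nM to 25000 nM. That expectation amounts to a 1.3-fold higher number from compound 1 to compound 3 (0.10 log units; within the scatter).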

Compound 3, half-maximal inhibitory concentration: 9600 nM
Compound 3: middle estimate off by 1.1-fold (0.05 log units), on the low side; low and high end bracket the measured number.
By their numbers in this assay, from the lowest: compounds 1, 3 and 2 (each within the scatter of the next).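

In this assay the exchange gives a 1.4-fold higher number from compound 1 to compound 3 (0.16 log units; within the scatter) and so shows that this place on the shared core tolerates more than a change to the amino group: the whole aromatic ring can differ. The carbon-only ring of 4-aminophenyl and its hydrogen-bond donor can give way to pyridin-3-yl with no change that can be read beyond the scatter. Nothing measured explains this result.

Still open, on these data alone, is whether a carboxylic acid in place of the amino group, or a piperidine ring in place of the aromatic ring, would move the number beyond the scatter.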